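The source may hold more compounds than are shown below. What is called first, only, known or untested is meant among the compounds shown, and "the series" means these compounds.

Of the compounds shown here, three that share one core have been measured in a physicochemical assay for pharmacokinetics; a lower number here means that the compound disappears faster, a higher number that the compound lasts longer. Compound 1 `O=C(NCc1cccc2ccccc12)N1C(=O)c2ccccc2S1(=O)=O` gives 0.395 h, compound 2 `O=C(NCc1ccccc1Br)N1C(=O)c2ccccc2S1(=O)=O` gives 0.253 h, and compound 3 `COc1cccc(CNC(=O)N2C(=O)c3ccccc3S2(=O)=O)c1` gives 0.523 h. Compound 2 and compound 1 lie within the usual scatter of each other, and only compound 3 stands clear of compound 2, on the longer-lasting side.

The compound still to be measured, compound 4 `Cc1ccccc1CNC(=O)N1C(=O)c2ccccc2S1(=O)=O`, differs from compound 2 in one place: methyl in place of bromo on an aromatic carbon. In plain words, this is methyl in place of bromo on an aromatic carbon, ortho to a large group, so 2-bromophenyl becomes 2-methylphenyl.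

Going by the values given here, one measured step bears on this change: a 2.1-fold higher number from compound 2 to compound 3 (0.32 log units; beyond the scatter). That step also removes the 2-bromophenyl, but what enters differs from the 2-methylphenyl of compound 4, so it is only a loose guide. Among the compounds with values here, no measured pair shows methyl and bromo exchanged directly. The guiding step points upward and is modest, so a small rise within the scatter is expected in this assay, though the direction is far from certain. The expected change is a 1.3-fold higher number from compound 2 to compound 4 (0.10 log units; within the scatter). For compound 4 the estimated half-life is 0.32 h, with an expected range from 0.19 h to 0.55 h.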

Compound 4, half-life: 0.792 h
Estimate against measurement, compound 4: 2.5-fold (0.39 log units) below; measured number outside the range, above it.
By their numbers in this assay, from the lowest: compounds 2, 1, 3 and 4 (each within the scatter of the next, the first and the last beyond it).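

In this assay, going by these compounds alone, the single exchange of bromo for methyl on an aromatic carbon, ortho to a large group, gives a 3.1-fold higher number from compound 2 to compound 4 (0.50 log units; beyond the scatter) and so provides the first direct reading of this change. One heavy atom replaces one heavy atom here, with no ring, hydrogen-bond donor, hydrogen-bond acceptor or net charge entering or leaving, yet that is enough to carry the half-life clear of the scatter. The 3-methoxyphenyl group is also no longer the only replacement for 2-bromophenyl that stands clear of compound 2, and a 1.5-fold higher number from compound 3 to compound 4 (0.18 log units; within the scatter) means that compound 3 and compound 4 cannot be told apart in this measurement. No measurement shown here explains why this exchange has the effect it does.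

From the compounds shown here alone, it remains open whether the rise belongs to methyl in particular or would also appear with chloro, fluoro, ethyl or methoxy on this same aromatic carbon. Going by these compounds, it is equally open what an amine or a carboxylic acid would do there, and whether methyl would give a similar result elsewhere on the ring.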